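This account rests on a few compounds, and the source may have more. Where it says the series, first, only, none or still open, it means among the compounds named here.

Measured compounds:
Compound 1, `CC1=C(C(=O)Nc2ccc(F)cc2)C(c2ccc([N+](=O)[O-])cc2)N=C(SCc2cccc(Cl)c2)N1`: 12.9%
Compound 2, `COc1ccc(C2N=C(SCc3ccc(F)cc3)NC(C)=C2C(=O)Nc2ccc(Br)cc2)cc1`: 19.1%
Compound 3, `CC1=C(C(=O)Nc2ccc([N+](=O)[O-])cc2)C(c2ccc(Br)cc2)N=C(SCc2ccccc2)N1`: 21.1%

In a functional assay on the whole organism (artery, strain albino) with Rattus norvegicus as the target, with a stated time of 720 min, at a dose of 10 mg/kg by the oral route (on this read-out lower numbers stand for less inhibition and higher numbers for more inhibition at the one dose given (going by the name of the read-out)), compound 3 gives 21.1%, the top figure of the three as read. Compound 2, with 19.1%, sits within the usual scatter of compound 3, and compound 1, with 12.9%, does so as well, so the three figures cannot be told apart with confidence. No two of these compounds differ in a single place, so nothing can be said about what any one change does on this read-out.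

Compound 4, `CC1=C(C(=O)Nc2ccc([N+](=O)[O-])cc2)C(c2ccc(Br)cc2)N=C(SCc2cccc(Cl)c2)N1`, has not yet been measured. It differs from compound 3 in one place: chloro in place of hydrogen on an aromatic carbon. The change turns the benzylsulfanyl group of compound 3 into a (3-chlorobenzyl)sulfanyl group, the same group that compound 1 carries, though compound 1 also differs from compound 4 elsewhere and its figure speaks only for itself.

For the measured compounds named here, with no step between measured compounds to lean on, the step from compound 3 to compound 4 in this assay is expected to stay within the scatter, a number 0.9 percentage points higher from compound 3 to compound 4 (within the scatter), in no firm direction. Compound 4 is therefore estimated at 22% in this assay, with a range from 8% to 36%.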

Compound 4, a percentage reported as inhibition, in the whole organism at one dose (the size of the read-out at that dose, not a potency): 2.6%
Estimate against measurement, compound 4: 19.4 percentage points above; measured number outside the range, below it.
By their numbers in this assay, from the lowest: compound 4; then compounds 1, 2 and 3 (each within the scatter of the next).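

In this assay, chloro in place of hydrogen on an aromatic carbon of the benzylsulfanyl group gives a number 18.5 percentage points lower from compound 3 to compound 4 (beyond the scatter) and is the first single change shown here, so this position on the benzyl group is one where replacing one hydrogen can take the read-out beyond the usual scatter. For the compounds shown here, the step is the only direct reading of this change, and it holds for one pair, with the nitro-bearing amide and the bromophenyl group of compound 3 left in place. Nothing available bears on why the figure falls with this change.

The compounds shown leave open whether a hydroxyl, an amine or a carboxylic acid at this position would give a similar step. They also leave open whether chloro would have the same effect on another carbon of that ring, or with other groups elsewhere on the shared core.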